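Chloro for fluoro on the bis-furan amidine

The compounds below may be only part of what the source reports. "The series", "measured", "known", "first", "only" and "open" are said of these compounds alone.

Compounds measured so far:
compound 1, `N=C(N)c1ccc(-c2ccc(-c3cncc4ccccc34)s2)s1`, 1650 nM
compound 2, `N=C(N)c1ccc(-c2ccc(-c3ccc(F)cc3)o2)o1`, 1360 nM

Both were tested in a functional assay on NCI-H522 cells (Homo sapiens) for inhibition, read by sulforhodamine B assay, with a stated time of 48 h; a lower number here means a stronger inhibitor of growth, a higher number a weaker inhibitor of growth. Compound 1 gives 1650 nM in this assay, and compound 2 gives 1360 nM. Compound 2 holds the lowest of the two numbers, but its nearest neighbour, compound 1, stands within the scatter of it, so no order between the two can be read from these values.

Compound 3, `N=C(N)c1ccc(-c2ccc(-c3ccc(Cl)cc3)o2)o1`, has not yet been measured. It differs from compound 2 by chloro in place of fluoro on an aromatic carbon, a chloro in place of fluoro on an aromatic carbon. No comparison of this kind exists among the measured compounds, so the size of the step is open. An exchange of one halogen for another at this position is expected to leave the number close to where it stands, and the step of a 1.2-fold lower number from compound 2 to compound 3 (0.09 log units; within the scatter) is estimated to be small, at most a slight lowering. For compound 3 in this assay the expected value is 1100 nM, in a range from 500 nM to 2500 nM.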

Compound 3, concentration for 50% growth inhibition: 1730 nM
Compound 3: middle estimate off by 1.6-fold (0.20 log units), on the low side; the range from low to high includes it.
By their numbers in this assay, from the lowest: compounds 2, 1 and 3 (each within the scatter of the next).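

In this assay, among the compounds shown here, the exchange of chloro for fluoro gives the first readable comparison at this position, on an aromatic carbon of a six-membered aromatic ring of carbon only, para to a large group (a 1.3-fold higher number from compound 2 to compound 3 (0.10 log units; within the scatter)). The step lies within the scatter, so compound 2 and compound 3 cannot be told apart, and this position accepts either halogen without a readable difference in this assay. Nothing available bears on why the two halogens give such similar numbers.

As far as these compounds go, whether a group of another kind at this position, such as an amine, a methoxy or a carboxylic acid, would move the number beyond the scatter remains open. From the compounds shown here alone, it also remains open whether the same halogen exchange would behave alike on the core of compound 1.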